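The source may hold more compounds than are shown below. What is called first, only, known or untested is meant among the compounds shown, and "the series" means these compounds.

Compound 1 `Cc1ccc(/C=N/N=C(\N)CC(O)c2cccc3ccccc23)cc1` and compound 2 `COc1ccc(/C=N/N=C(\N)CC(O)c2cccc3ccccc23)cc1` share one core and differ only at a single spot on the outer ring: methyl in place of methoxy on an aromatic carbon. In an ADME assay on L6 cells (Rattus norvegicus) for cytotoxicity, read by resazurin assay, with a stated time of 72 h (on this read-out higher numbers stand for weaker inhibition and lower numbers for stronger inhibition), compound 2 gives 6300 nM, and compound 1 gives 6800 nM; the resulting move, a 1.1-fold higher number from compound 2 to compound 1 (0.03 log units; within the scatter), is too small to mean anything. Compound 3 `COc1ccc(/C=N/N=C(\N)CC(O)c2ccc3ccccc3c2)cc1` is built from the same atoms as compound 2 but joined in a different way, and the difference between the two cores is not broken down here. In this assay compound 3 gives 69000 nM, the highest of the three numbers and well apart from both others.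

Compound 4 `Cc1ccc(/C=N/N=C(\N)CC(O)c2ccc3ccccc3c2)cc1` carries the core of compound 3 with the same small change already seen between compound 2 and compound 1: methyl in place of methoxy on an aromatic carbon. Since that earlier swap barely moved the read-out, the step of a 1.1-fold higher number from compound 3 to compound 4 (0.04 log units; within the scatter) is expected to be similarly small, resting on a 1.1-fold higher number from compound 2 to compound 1 (0.03 log units; within the scatter). Compound 4 is therefore estimated at 75000 nM, plausibly between 35000 nM and 160000 nM, close to compound 3.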

Compound 4, half-maximal inhibitory concentration: 103000 nM
Compound 4: middle estimate off by 1.4-fold (0.14 log units), on the low side; measured number inside the range.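

On the core of compound 3, putting methyl in place of methoxy gives a 1.5-fold higher number from compound 3 to compound 4 (0.17 log units; within the scatter) in this assay. Set beside the same swap on the core of compound 1, the two results cannot be told apart, so in this assay the swap carries from one core to the other without a readable effect: the same change on two cores in this assay, a 1.1-fold higher number (0.03 log units; within the scatter) from compound 2 to compound 1 and a 1.5-fold higher number (0.17 log units; within the scatter) from compound 3 to compound 4, 1.4-fold (0.14 log units) apart, within the scatter of two such steps This rests on only two pairs, both with the group on an aromatic carbon para to a large group, so it does not show that the swap would behave the same way on other cores or in other assays, or that methyl and methoxy are truly equal here.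

The compounds shown carry only methoxy and methyl at this spot, so it remains open whether an amine, a carboxylic acid or a longer chain there would leave the read-out just as unmoved. Also open, as far as these compounds go, is whether a smaller atom such as fluorine would do the same on either core.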